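Alkyl variation on the shared core: compound 4 expected

The compounds below may be only part of what the source reports. "The series", "measured", "known", "first", "only" and "open" are said of these compounds alone.

Measured so far in a functional assay on MCF7 cells (Homo sapiens) for cytotoxicity, read by MTT assay, with a stated time of 72 h; on this read-out lower numbers stand for stronger inhibition and higher numbers for weaker inhibition:
- Compound 1 `Cc1nnc2nnc(N3CCCC3)nn12` gives 44800 nM in this assay.
- Compound 2 `CC(C)(C)c1nnc2nnc(N3CCCC3)nn12` gives 55000 nM in this assay.
- Compound 3 `C1CCC(c2nnc3nnc(N4CCCC4)nn23)CC1` gives 37700 nM in this assay.

All three carry the same core and differ only in the group on one aromatic carbon. Compound 3 is not set apart from the other two on the numbers shown: a 1.2-fold lower number from compound 1 to compound 3 (0.07 log units; within the scatter) and a 1.5-fold lower number from compound 2 to compound 3 (0.16 log units; within the scatter) are both within the scatter, as is a 1.2-fold higher number from compound 1 to compound 2 (0.09 log units; within the scatter). The three alkyl groups tried so far, methyl, tert-butyl and cyclohexyl, thus give one common level in this assay.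

Compound 4 `CCCCCc1nnc2nnc(N3CCCC3)nn12` is not yet measured. Relative to compound 3 the change is pentyl in place of cyclohexyl on an aromatic carbon. Every measured step in the series is an exchange of one alkyl group for another at this same carbon, and none of them moved this assay beyond the scatter. The step to compound 4 is of the same kind, so no shift beyond the scatter is expected; the estimate is a 1.1-fold higher number from compound 3 to compound 4 (0.05 log units; within the scatter) from compound 3 to compound 4.

For compound 4 the expected value in this assay is 42000 nM, with a range from 20000 nM to 90000 nM.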

Compound 4, half-maximal inhibitory concentration: 42900 nM
For compound 4 the middle estimate is 1.0-fold (0.01 log units) below the measured one; low and high end bracket the measured number.
By their numbers in this assay, from the lowest: compounds 3, 4, 1 and 2 (each within the scatter of the next).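

An open chain at this aromatic carbon stands on the same level as the ring it replaces in this assay, as pentyl in place of cyclohexyl gives a 1.1-fold higher number from compound 3 to compound 4 (0.06 log units; within the scatter) and so adds a ring-free group to the series without a step beyond the scatter. Pentyl also stays level with the branched tert-butyl (a 1.3-fold lower number from compound 2 to compound 4 (0.11 log units; within the scatter)) and with the much shorter methyl (a 1.0-fold lower number from compound 1 to compound 4 (0.02 log units; within the scatter)), so the common level now spans ring, branched and unbranched alkyl groups at this position, and compounds 1, 2, 3 and 4 cannot be separated on these numbers. No measurement at hand speaks to what lies behind this flat picture.

As far as these compounds go, all four groups here are purely carbon substituents without hydrogen-bond donors or acceptors, so it remains open whether an amine, a carboxylic acid or a phenyl ring on this same carbon would give a step beyond the scatter in this assay. From the compounds shown here alone, the rest of the shared core is identical across the four compounds, so what an exchange elsewhere on it would do also remains open.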